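The compounds below may be only part of what the source reports. "The series", "measured", "known", "first", "only" and "open" are said of these compounds alone.

In an ADME assay on CHO cells (Cricetulus griseus) for cytotoxicity, read by LDH release (on this read-out lower numbers stand for stronger inhibition and higher numbers for weaker inhibition), compound 1 `CC(Oc1ccc(Cl)cc1Cl)C(=O)NCc1ccccc1` gives 95000 nM, compound 2 `CC(Oc1ccc(Cl)cc1Cl)C(=O)NCc1cccc(F)c1` gives 27000 nM and compound 3 `Cc1ccc(CNC(=O)C(C)Oc2ccc(Cl)cc2Cl)cc1` gives 25000 nM. Compound 3 thus stands level with compound 2, as a 1.1-fold lower number from compound 2 to compound 3 (0.03 log units; within the scatter) shows, and both sit well under compound 1. Compound 4 `CC(Oc1ccc(Cl)cc1Cl)C(=O)NCc1ccc(F)cn1` brings 5-fluoropyridin-2-yl in place of 4-methylphenyl on a saturated chain carbon bound to an amide-type nitrogen: 5-fluoropyridin-2-yl in place of 4-methylphenyl. Going by the values given here, no measured compound carries a ring with a hetero atom, so only a 3.5-fold lower number from compound 1 to compound 2 (0.55 log units; beyond the scatter) and a 3.8-fold lower number from compound 1 to compound 3 (0.58 log units; beyond the scatter) bear on this change, both modest. Compound 4 keeps a fluoro group, as compound 2 does at 27000 nM, so only a small rise is expected, with a 1.6-fold higher number from compound 3 to compound 4 (0.20 log units; within the scatter) as the expected step. For compound 4 the estimated value is 40000 nM, with an expected range of 15000 nM to 110000 nM.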

Compound 4, half-maximal inhibitory concentration: > 100000 nM
Compound 4 ended at the assay's limit; the forecaster's own chance of this, stated with the estimate: 15%; at least 2.5-fold (0.39 log units) between middle value and limit.
By their numbers in this assay, from the lowest: compounds 3 and 2 (each within the scatter of the next); then compound 1. At a limit, above all of these: compound 4.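

In this assay compound 4 reads as a limit and not as a number: the limit of > 100000 nM in this assay, at which 1 of the 4 values shown sits.

Here a ring with a hetero atom, on a saturated chain carbon bound to an amide-type nitrogen, runs against the lower numbers seen with the 3-fluorophenyl and 4-methylphenyl groups, with an at least 4.0-fold higher number from compound 3 to compound 4 (0.60 log units; beyond the scatter) and an at least 3.7-fold higher number from compound 2 to compound 4 (0.56 log units; beyond the scatter). Against phenyl nothing can be told, with an at least 1.0-fold higher number from compound 1 to compound 4 (0.02 log units; that floor lies within the scatter).

The compounds shown leave open whether the ring nitrogen alone accounts for this step. A pyridin-2-yl group without the fluoro group, or a phenyl group carrying an amine, could separate the two changes.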